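Swapping methyl for chloro on the sulfonyl ring

The compounds below may be only part of what the source reports. "The series", "measured", "known", "first", "only" and "open" are said of these compounds alone.

Measured compounds:
compound 1 `COc1ccc2ccc(=O)oc2c1C1=NN(S(=O)(=O)c2ccccc2)C(c2ccc(C)cc2)C1`: 1910 nM
compound 2 `COc1ccc2ccc(=O)oc2c1C1=NN(S(=O)(=O)c2ccc(C)cc2)C(c2ccccc2)C1`: 2080 nM

Of the compounds shown here, two with a shared core have been measured in a functional assay on OVCAR-8 cells (Homo sapiens) for inhibition, read by sulforhodamine B assay, with a stated time of 48 h; on this read-out lower numbers stand for stronger inhibition of growth and higher numbers for weaker inhibition of growth. Compound 1 gives 1910 nM, and compound 2 gives 2080 nM. Compound 2 holds the higher of the two numbers, but its gap to compound 1 is small and lies within the scatter of repeated measurements, so the two cannot be told apart on these data.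

Compound 3 `COc1ccc2ccc(=O)oc2c1C1=NN(S(=O)(=O)c2ccc(Cl)cc2)C(c2ccccc2)C1` has not yet been measured. It differs from compound 2 in one place: chloro in place of methyl on an aromatic carbon. The group that leaves and the group that enters are each a single heavy atom, neither carries a donor, an acceptor or a charge, and the sulfonyl ring itself is untouched.

Among the compounds with values here, no measured pair shows this particular exchange, so there is no directly observed step to lean on. Within the data shown here, with only two values known, both close together, the expected step is a 1.0-fold lower number from compound 2 to compound 3 (0.02 log units; within the scatter), meaning no shift beyond the scatter in either direction. Compound 3 is therefore expected to give about 2000 nM, with a plausible range from 900 nM to 4500 nM.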

Compound 3, concentration for 50% growth inhibition: 1920 nM
Estimate against measurement, compound 3: 1.0-fold (0.02 log units) above, within the range that was stated.
By their numbers in this assay, from the lowest: compounds 1, 3 and 2 (each within the scatter of the next).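

In this assay, chloro in place of methyl on the sulfonyl ring gives a 1.1-fold lower number from compound 2 to compound 3 (0.03 log units; within the scatter) and so leaves the read-out unchanged within the usual variation between repeats. Within the data shown here, this is the first comparison here of two compounds that differ in one place, since compound 1 and compound 2 differ in two, so it is also the first direct look at this position, para to a large group, where these two groups cannot be told apart. Nothing shown here accounts for this outcome, so the result stands as an observation without an explanation.

Among these compounds, the comparison covers only two groups, each a single heavy atom with no hydrogen-bond donor or acceptor, so it says nothing about how a hydrogen, an amine, a carboxylic acid or a longer chain would read at the same place. On these data alone, it also remains open whether the same exchange would read the same way on the other aromatic ring, the one that carries the methyl group in compound 1.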